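Aryl variation at the bicyclic core: growth inhibition notes

A few compounds are considered here, and "the series" means these few. Any claim that something is new, unique, unknown or untested is made for them only; others in the source may bear on it.

Growth inhibition in a functional assay on NCI-H460 cells (Homo sapiens) for inhibition, read by sulforhodamine B assay, with a stated time of 48 h (on this read-out lower numbers stand for stronger inhibition of growth and higher numbers for weaker inhibition of growth), for the three measured compounds:
- compound 1 `COC(=O)c1sc2cc(-c3cccs3)cnc2c1N`: 18000 nM
- compound 2 `COC(=O)c1sc2cc(-c3ccc4ccccc4c3)cnc2c1N`: 43500 nM
- compound 3 `COC(=O)c1sc2cc(-c3ccc4c(ccn4C)c3)cnc2c1N`: 20300 nM

Compound 1 gives the lowest number of the three. Compound 3 sits within the usual scatter of compound 1, so no order between these two can be stated. Compound 2 lies beyond the scatter from compound 1, and is the only one of the set to do so; all three remain weak inhibitors in this assay.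

The next compound, compound 4 `COC(=O)c1sc2cc(-c3ccc(N)cc3)cnc2c1N`, differs from compound 1 at one position: 4-aminophenyl in place of thiophen-2-yl on an aromatic carbon. Among the measured compounds shown here, no measured pair in the set shows this kind of exchange, so nothing on file fixes its size. The three measured aryl groups span a modest range, and the six-membered ring entering here is of comparable size to the groups already seen. The step from compound 1 to compound 4 is therefore expected to be small, most likely within the scatter, with no firm direction; the expected step is a 1.2-fold lower number from compound 1 to compound 4 (0.08 log units; within the scatter). On that basis compound 4 is estimated at 15000 nM in this assay, with a range from 5000 nM to 45000 nM.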

Compound 4, concentration for 50% growth inhibition: 37100 nM
Compound 4: middle estimate off by 2.5-fold (0.39 log units), on the low side; low and high end bracket the measured number.
By their numbers in this assay, from the lowest: compounds 1, 3, 4 and 2 (each within the scatter of the next, the first and the last beyond it).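

In this assay, among the compounds shown here, 4-aminophenyl in place of thiophen-2-yl on this aromatic carbon gives a 2.1-fold higher number from compound 1 to compound 4 (0.31 log units; beyond the scatter) as the first readable step at this position, a modest one that shows the exchange of one aromatic group for another can weaken growth inhibition. The exchange replaces a five-membered aromatic ring with 1 hetero atom by a six-membered aromatic ring of carbon only and also adds a hydrogen-bond donor, so this one step cannot separate the ring from the amine. Nothing measured here explains the step.

Plain phenyl on the same core would show how much of the step belongs to the ring alone, and 4-hydroxyphenyl or 4-methoxyphenyl would test other groups in the place of the amine. As far as these compounds go, the shared core's methyl ester, which a carboxylic acid or an amide could replace, also remains open.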